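This account rests on a few compounds, and the source may have more. Where it says the series, first, only, none or still open, it means among the compounds named here.

In a functional assay on LNCaP cells (Homo sapiens) for antiproliferative activity, read by CCK-8 assay, with a stated time of 6 days (a higher number here means a weaker inhibitor, a lower number a stronger inhibitor), compound 1 `C[C@@H](Cn1ccc(-c2ccc(C#N)c(Cl)c2)n1)NC(=O)c1ccccc1` gives 1830 nM, and compound 2 `C[C@@H](Cn1ccc(-c2ccc(C#N)c(Cl)c2)n1)Nc1ccccn1` gives 1110 nM. Compound 2 holds the lowest of these two numbers, although the step of a 1.6-fold lower number from compound 1 to compound 2 (0.22 log units; within the scatter) lies within the scatter. Compound 3 `C[C@@H](Cn1ccc(-c2ccc(C#N)c(Cl)c2)n1)Nc1cncnc1` differs from compound 2 by pyrimidin-5-yl in place of pyridin-2-yl on an amine nitrogen. Among the compounds with values here, the only measured step at that amine nitrogen, from a benzoyl to a pyridin-2-yl group, stayed within the scatter, and no measured step exchanges one six-membered aromatic ring for another. Accordingly a step of a 1.2-fold higher number from compound 2 to compound 3 (0.07 log units; within the scatter) is expected in this assay, nothing beyond the scatter. Compound 3 is therefore estimated at 1300 nM, with a range from 500 nM to 3500 nM.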

Compound 3, half-maximal inhibitory concentration: 2070 nM
For compound 3 the middle estimate is 1.6-fold (0.20 log units) below the measured one, within the range that was stated.
By their numbers in this assay, from the lowest: compounds 2, 1 and 3 (each within the scatter of the next).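

Within the data shown here, at the amine nitrogen, this is the first exchange of one six-membered aromatic ring for another, and in this assay it gives a 1.9-fold higher number from compound 2 to compound 3 (0.27 log units; within the scatter). The comparison with the benzoyl group gives a 1.1-fold higher number from compound 1 to compound 3 (0.05 log units; within the scatter). Benzoyl, pyridin-2-yl and pyrimidin-5-yl therefore cannot be told apart on this nitrogen in this range of values. As far as these compounds go, whether a methyl or acetyl group, or an unsubstituted amine, on this nitrogen would shift the number beyond the scatter remains open. Nothing available explains these numbers.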